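The compounds below may be only part of what the source reports. "The series", "measured", "known", "first", "only" and "open" are said of these compounds alone.

Two chalcone-type anilides were assayed in a functional assay on MCF7 cells (Homo sapiens) for cytotoxicity, read by MTT assay, with a stated time of 72 h; on this read-out lower numbers stand for stronger inhibition and higher numbers for weaker inhibition. Compound 1 `O=C(CCl)Nc1ccc(C(=O)/C=C/c2ccccc2Cl)cc1` carries a chloroacetamide on the aniline and a 2-chlorophenyl on the enone; in this assay compound 1 gives 5260 nM. Compound 2 `O=C(CSC(=S)N[C@H]1CCOC1=O)Nc1ccc(C(=O)/C=C/c2ccccc2)cc1` instead bears the dithiocarbamate-linked lactone on the acetamide and a plain phenyl on the enone; in this assay compound 2 gives 44300 nM, the higher of the two numbers, and compound 1 stands at a lower number by a margin beyond the scatter. The two compounds differ at two places. Going by the values given here, no single step between them can be read.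

Compound 3 `O=C(CSC(=S)N[C@H]1CCOC1=O)Nc1ccc(C(=O)/C=C/c2ccccc2Cl)cc1` is the next member. Its difference from compound 2 is chloro in place of hydrogen on an aromatic carbon, placed on an aromatic carbon of a six-membered aromatic ring of carbon only, ortho to a large group. Among the compounds with values here, no measured pair shows this change on its own, so for the step from compound 2 to compound 3 in this assay a modest move toward a lower number is expected, possibly no larger than the scatter. Compound 3 is therefore estimated at 28000 nM, within 9000 nM to 90000 nM, an expected step of a 1.6-fold lower number from compound 2 to compound 3 (0.20 log units; within the scatter).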

Compound 3, half-maximal inhibitory concentration: 5570 nM
Estimate against measurement, compound 3: 5.0-fold (0.70 log units) above; the measured number lies below the stated range.
By their numbers in this assay, from the lowest: compounds 1 and 3 (each within the scatter of the next); then compound 2.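

In this assay, going by these compounds alone, the change from phenyl to 2-chlorophenyl, with the dithiocarbamate-linked lactone kept on the acetamide, gives an 8.0-fold lower number from compound 2 to compound 3 (0.90 log units; beyond the scatter), the first reading of this position on its own, and it shows that a single chlorine here is enough for a step beyond the scatter. With the 2-chlorophenyl held in place, replacing the chlorine on the saturated chain carbon bound to a carbonyl carbon by the group of 10 heavy atoms gives a 1.1-fold higher number from compound 1 to compound 3 (0.02 log units; within the scatter), so these two very different groups cannot be told apart in this read-out when the 2-chlorophenyl is present. Nothing available here bears on why the chloro step is this large.

The compounds shown leave open whether fluoro, methyl or methoxy at this place would give a step of similar size, and whether chloro on another carbon of the same ring would do so. They also leave open whether the same chloro step would appear with the chloroacetamide, or with an amine or a longer chain on the acetamide.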